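The source may report more compounds than this note shows. Statements on the series, on what has been measured and on what is new or still open speak of the compounds shown alone.

Compound 1, `O=C(Nc1ccc(OC(F)(F)F)cc1)NC1CCN(C(=O)c2ccoc2)CC1`, is the more soluble of the two compounds measured here. In a physicochemical assay for solubility, read by mass spectrometry, in phosphate buffer, with a stated time of 24 h, at pH 7.4 (a higher number here means a more soluble compound, a lower number a less soluble compound), compound 1 gives 7.6 ug/mL, the higher of the two numbers, while compound 2, `O=C(Nc1ccc(C(F)(F)F)cc1)NC1CCN(C(=O)C2=COCC2)CC1`, gives 2.3 ug/mL, a gap that lies beyond the usual scatter. No single-point change between measured compounds is available for guidance.

Compound 3, `O=C(Nc1ccc(OC(F)(F)F)cc1)NC1CCN(C(=O)C2CCCOC2)CC1`, is not yet measured. It differs from compound 1 in one place only: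

oxan-3-yl in place of furan-3-yl on a carbonyl carbon

In this assay the step from compound 1 to compound 3 is expected to be a modest rise, a 2.0-fold higher number from compound 1 to compound 3 (0.30 log units; within the scatter), though a result within the scatter of the value of compound 1 would not be surprising, because only 7.6 ug/mL anchors the comparison. On that basis compound 3 is estimated at 15 ug/mL, with a range from 5 ug/mL to 45 ug/mL.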

Compound 3, solubility: 94 ug/mL
The estimate for compound 3 lay 6.3-fold (0.80 log units) below the measured number; the whole stated range lies below it.
By their numbers in this assay, from the lowest: compound 2; then compound 1; then compound 3.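

In this assay the swap at the carbonyl carbon gives a 12-fold higher number from compound 1 to compound 3 (1.09 log units; beyond the scatter) and so shows that this position, on which no earlier single change bore, can move the number strongly. The step replaces a five-membered aromatic ring with a six-membered non-aromatic ring, while the hydrogen-bond donor and acceptor counts and the absence of net charge stay the same in the two groups. No available evidence explains the size of this step.

Ring size and aromatic character change together in this single step, so the compounds shown cannot separate them, and oxolan-3-yl would be the natural group to tell them apart. As far as these compounds go, it also remains open whether oxan-4-yl, or a ring bearing an amine or a carboxylic acid, would behave like oxan-3-yl at this carbonyl carbon.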